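The compounds below may be only part of what the source reports. "The series", "measured", "known", "first", "only" and "open" are said of these compounds alone.

Measured compounds:
Compound 1, `CC(C)c1nn(-c2ccc(C(N)=O)c(N[C@H]3CC[C@H](O)CC3)c2)c2nccc(-n3cnc(-c4ccncc4)c3)c12`: 165 nM
Compound 2, `CNc1cc(C(N)=O)ccc1-n1nc(C(C)C)c2c(-n3cnc(-c4cnn(C)c4)c3)ccnc21`: 419 nM
Compound 3, `CC(C)c1nn(-c2ccc(C(N)=O)c(N[C@H]3CC[C@H](O)CC3)c2)c2ccnc(-c3cnc4ccccc4c3)c12`: 1720 nM

In a functional assay on SK-BR-3 cells (Homo sapiens) for inhibition, read by CellTiter-Glo, with a stated time of 72 h (on this read-out higher numbers stand for weaker inhibition and lower numbers for stronger inhibition), compound 1 gives 165 nM, the lowest number of the three and therefore the strongest inhibition. Compound 2 stands nearest, and its higher number lies beyond the usual scatter of repeated measurements; compound 3 stands furthest, its number also beyond the scatter. Compound 1 is thus the most potent of the measured set.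

Compound 4, `CC(C)c1nn(-c2ccc(C(N)=O)c(N[C@H]3CC[C@H](O)CC3)c2)c2nccc(-c3ccc4ccccc4c3)c12`, has not yet been measured in this assay. It differs from compound 1 in one place: naphthalen-2-yl in place of 4-(pyridin-4-yl)-1H-imidazol-1-yl on an aromatic carbon. The group that leaves carries hydrogen-bond acceptors; the group that enters carries none and is made of carbon only. Within the data shown here, no pair of measured compounds shows this change, so no directly comparable step exists. The step from compound 1 to compound 4 is expected to go toward weaker inhibition, beyond the scatter: a 6.1-fold higher number from compound 1 to compound 4 (0.78 log units; beyond the scatter). Compound 4 is expected to give about 1000 nM in this assay, within a range from 300 nM to 4000 nM.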

Compound 4, half-maximal inhibitory concentration: > 10000 nM
Compound 4 ended at the assay's limit (the forecaster's own chance of this, stated with the estimate: 10%); at least 10-fold (1.00 log units) between middle value and limit.
By their numbers in this assay, from the lowest: compound 1; then compound 2; then compound 3. At a limit, above all of these: compound 4.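

In this assay compound 4 gives > 10000 nM, which is a limit of the assay and not a number: the limit of > 10000 nM in this assay, at which 1 of the 4 values shown sits. On the aromatic carbon opposite the ring nitrogen, naphthalen-2-yl in place of 4-(pyridin-4-yl)-1H-imidazol-1-yl gives an at least 60-fold higher number from compound 1 to compound 4 (1.78 log units; beyond the scatter). Among these compounds, the earlier compounds offered no single-place step, so this is the first direct sign that inhibition on this read-out depends strongly on the group at this position, and that a carbon-only pair of rings does not stand in for the group carrying hydrogen-bond acceptors.

The compounds shown do not tell which part of the group that leaves matters, the imidazole ring or the pyridine ring. A plain 1H-imidazol-1-yl without its pyridin-4-yl ring, or a naphthalen-2-yl carrying an amine, would begin to separate these possibilities.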